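The source may report more compounds than this note shows. Statements on the series, on what has been measured and on what is new or still open speak of the compounds shown alone.

Among the compounds with values here, compound 2 `Cc1nc(N)sc1CCCNC(=N)NC(=O)C[C@H](C)c1ccccc1` gives 28.2 nM in an in vitro functional assay on Sf9 cells for agonist activity at histamine H2 receptor (Homo sapiens), read by GTPgammaS binding (a higher number here means that more compound is needed for the effect, a lower number that less compound is needed), the lowest of two numbers so far; its nearest neighbour is compound 1 `Cc1nc(N)sc1CCCNC(=N)NC(=O)C[C@H](C)C1CCCCC1`, which gives 28.8 nM, and the step of a 1.0-fold lower number from compound 1 to compound 2 (0.01 log units; within the scatter) lies within the scatter. Compound 3 `C[C@@H](CC(=O)NC(=N)NCCCc1c[nH]cn1)c1ccccc1` differs from compound 2 by 1H-imidazol-4-yl in place of 2-amino-4-methyl-1,3-thiazol-5-yl on a saturated chain carbon, three bonds along the chain from an amine nitrogen. Within the data shown here, the only measured step changes a different part of the molecule, so none bears on this exchange, and no direction can be predicted beyond the scatter. Compound 3 is therefore estimated at 30 nM, within 8 nM to 120 nM, a step of a 1.1-fold higher number from compound 2 to compound 3 (0.03 log units; within the scatter) from compound 2.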

Compound 3, half-maximal effective concentration: 79.4 nM
Estimate against measurement, compound 3: 2.6-fold (0.42 log units) below; the range from low to high includes it.
By their numbers in this assay, from the lowest: compounds 2 and 1 (each within the scatter of the next); then compound 3.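

The ring at the end of the three-carbon chain matters here, unlike the phenyl and cyclohexyl exchange: 1H-imidazol-4-yl in place of 2-amino-4-methyl-1,3-thiazol-5-yl gives a modest change beyond the scatter (a 2.8-fold higher number from compound 2 to compound 3 (0.45 log units; beyond the scatter)). Both groups are five-membered aromatic rings with two hetero atoms, so those shared features alone do not fix the number. Nothing measured here explains the shift.

Still open, as far as these compounds go, is whether the amino group or the methyl group on the thiazole carries the difference, which a 1,3-thiazol-5-yl bearing only one of them could test. Also open, from the compounds shown here alone, is whether the exchange gives a similar step with cyclohexyl in place of phenyl.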